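Amide and urea carbonyl substituents on the shared core

This account rests on a few compounds, and the source may have more. Where it says the series, first, only, none or still open, it means among the compounds named here.

Compound 3 `O=C(N1CCCCC1)N1CC(c2nc(-c3cccc(Cl)c3)no2)C1`, carrying a piperidin-1-yl group on the carbonyl carbon, gives 370 nM in an assay on HEK293 cells for positive allosteric modulation of metabotropic glutamate receptor 5 (Homo sapiens), read by FLIPR (on this read-out higher numbers stand for an effect only at larger amounts of compound and lower numbers for an effect already at smaller amounts), the lowest of the two numbers seen so far. Compound 1 `O=C(C1CCCCC1)N1CC(c2nc(-c3cccc(F)c3)no2)C1` gives 1000 nM in this assay, a higher number than compound 3 and beyond the scatter. Compound 2 `O=C(c1ccccc1F)N1CC[C@H]1c1nc(-c2cccc(F)c2)no1` gives only > 10000 nM in this assay, which is a limit of the assay and not a number (the limit of > 10000 nM in this assay, at which 1 of the 3 values shown sits). Compound 4 `O=C(C1CCC(F)(F)CC1)N1CC(c2nc(-c3cccc(Cl)c3)no2)C1` is not yet measured; it differs from compound 3 by 4,4-difluorocyclohexyl in place of piperidin-1-yl on a carbonyl carbon. Within the data shown here, no measured pair isolates this change, so the expected step from compound 3 to compound 4 is small, a 1.4-fold higher number from compound 3 to compound 4 (0.13 log units; within the scatter), in neither direction clearly beyond the scatter. Compound 4 is therefore estimated at 500 nM, with a range from 150 nM to 1800 nM.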

Compound 4, half-maximal effective concentration: 180 nM
Beside the measured number, compound 4's estimate is 2.8-fold (0.44 log units) above it; measured number inside the range.
By their numbers in this assay, from the lowest: compound 4; then compound 3; then compound 1. At a limit, above all of these: compound 2.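

With the rest of compound 3 unchanged, 4,4-difluorocyclohexyl in place of piperidin-1-yl on the carbonyl carbon gives a 2.1-fold lower number from compound 3 to compound 4 (0.31 log units; beyond the scatter) in this assay. This first isolated change at this position is modest, and it shows that the amide-type nitrogen of the piperidin-1-yl group is not required on this carbonyl carbon for activity in this pair. Nothing in the data shown accounts for the step.

Open, going by these compounds, is where plain cyclohexyl would stand on the core of compound 4. Also open, on these data alone, is where 4,4-difluoropiperidin-1-yl would stand on the same carbonyl carbon.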